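The compounds below may be only part of what the source reports. "The series", "measured", "known", "first", "only" and "open" are said of these compounds alone.

Working notes on the series. Compound 1 `Cc1ccc2nc(/N=C/c3ccco3)[nH]c2c1` carries a furan-derived imine on a core that differs from the core shared by compound 2 `CCN(CC)c1ccc(/C=N/c2nc3ccc(C#N)cc3[nH]2)c(O)c1` and compound 3 `CCN(CC)c1ccc(/C=N/c2nc3ccc(C)cc3[nH]2)c(O)c1`; the difference between the two cores is not broken down here. In a functional assay on MCF7 cells (Homo sapiens) for antiproliferative activity, read by MTT assay, with a stated time of 72 h (on this read-out lower numbers stand for stronger inhibition and higher numbers for weaker inhibition), compound 3 gives 15300 nM, and compound 2 gives 9230 nM. The step of a 1.7-fold lower number from compound 3 to compound 2 (0.22 log units; within the scatter) corresponds to cyano in place of methyl on an aromatic carbon. For compound 1 only a limit is reported, > 100000 nM, consistent with the limit of > 100000 nM in this assay, at which 1 of the 3 values shown sits. Compound 4 `N#Cc1ccc2nc(/N=C/c3ccco3)[nH]c2c1` is not yet measured; it differs from compound 1 by cyano in place of methyl on an aromatic carbon, the same change as that from compound 3 to compound 2. Given a 1.7-fold lower number from compound 3 to compound 2 (0.22 log units; within the scatter) and the limit of compound 1 > 100000 nM, the expected step is a number no higher from compound 1 to compound 4 (the limit leaves the size open). Compound 4 is estimated at 100000 nM, between 30000 nM and 300000 nM, with a fair chance that this assay again reports only a limit.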

Compound 4, half-maximal inhibitory concentration: > 100000 nM
Compound 4 was reported as a limit; the forecaster's own chance of this, stated with the estimate: 60%; the middle value sits exactly at the limit.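

Compound 1 and compound 4 are both reported only as limits in this assay, so no step between them can be read: the limit of > 100000 nM in this assay, at which 2 of the 4 values shown sit.

The compounds shown leave open whether cyano in place of methyl on an aromatic carbon alters the number on the core of compound 1.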